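A few compounds are considered here, and "the series" means these few. Any claim that something is new, unique, unknown or untested is made for them only; others in the source may bear on it.

The three measured compounds and their readings:

Compound 1, `COc1cc2cc(Oc3ccc(NC(=O)Nc4ccc(C)cc4)cc3)c(C)nc2cc1OC`, gives 100%.
Compound 2, `COc1cc2cc(Oc3ccc(NC(=O)Nc4ccc(C(F)(F)F)cc4)cc3)c(C)nc2cc1OC`, gives 47.4%.
Compound 3, `COc1cc2cc(Oc3ccc(NC(=O)Nc4cccc(C(F)(F)F)c4)cc3)c(C)nc2cc1OC`, gives -86.1%.

These readings come from a functional assay on SK-MEL-5 cells (Homo sapiens) for inhibition, read by sulforhodamine B assay, with a stated time of 48 h, tested at 10 uM; a higher number here means a weaker effect of the compound at the concentration tested, a lower number a stronger effect. On the numbers shown, compound 1 stands highest of the three, with compound 2 nearest and compound 3 furthest from it. The step from compound 1 to compound 2 was a number 52.6 percentage points lower from compound 1 to compound 2 (beyond the scatter), and the step from compound 1 to compound 3 was a number 186.1 percentage points lower from compound 1 to compound 3 (beyond the scatter); the two trifluoromethyl isomers are themselves separated by a number 133.5 percentage points lower from compound 2 to compound 3 (beyond the scatter).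

Compound 4, `COc1cc2cc(Oc3ccc(NC(=O)Nc4ccc(Cl)c(C(F)(F)F)c4)cc3)c(C)nc2cc1OC`, has not yet been measured. It differs from compound 1 in one place: 4-chloro-3-(trifluoromethyl)phenyl in place of 4-methylphenyl on an amide-type nitrogen. Both measured steps away from compound 1 bear on this change, since compound 4 carries a trifluoromethyl group in the same position on the ring as compound 3, together with an added chlorine. Both steps were large and downward, so a large downward step in this assay is expected for compound 4 as well. The step from compound 1 to compound 4 is estimated at a number 160 percentage points lower from compound 1 to compound 4 (beyond the scatter), and compound 4 is expected to read about -60%, within a range from -120% to 20%.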

Compound 4, a percentage reported as activity, at one concentration (the size of the read-out at that concentration, not a potency): -73.4%
Beside the measured number, compound 4's estimate is 13.4 percentage points above it; the range from low to high includes it.
By their numbers in this assay, from the lowest: compound 3; then compound 4; then compound 2; then compound 1.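

In this assay, chloro in place of hydrogen on an aromatic carbon produced a reading that was a number 12.7 percentage points higher from compound 3 to compound 4 (beyond the scatter), so this added group weakened the effect only modestly and gave the first sign that the aryl group on the amide-type nitrogen can carry a second substituent without losing most of the effect. The 4-chloro-3-(trifluoromethyl)phenyl group also kept the large gain over the 4-methylphenyl group, with a reading a number 173.4 percentage points lower from compound 1 to compound 4 (beyond the scatter), and over the 4-(trifluoromethyl)phenyl group, with a reading a number 120.8 percentage points lower from compound 2 to compound 4 (beyond the scatter). Among these compounds, both aryl groups that carry trifluoromethyl at the 3 position of the name therefore stand well apart from compound 1 and compound 2, though nothing available explains why the added chloro shifts the reading as it does.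

The compounds shown leave open how a 4-chlorophenyl group without trifluoromethyl would read, and so how much of the effect of compound 4 depends on each of its two substituents. They also leave open whether a methoxy group, a nitrile or an amine could take the place of the chloro while keeping the effect seen with compound 4.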